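Ester chain variation on a diisopropylanilide malonamate series

This account rests on a few compounds, and the source may have more. Where it says the series, first, only, none or still open, it means among the compounds named here.

Measured so far:
- compound 1 `CCCCCCCCOC(=O)CC(=O)Nc1c(C(C)C)cccc1C(C)C`: 260 nM
- compound 2 `CC(C)c1cccc(C(C)C)c1NC(=O)CC(=O)O`: > 5000 nM
- compound 3 `CCCCCC(C)OC(=O)CC(=O)Nc1c(C(C)C)cccc1C(C)C`: 27 nM

In an assay on microsomes from intestine for inhibition of acyl-CoA:cholesterol acyltransferase (Oryctolagus cuniculus) (a higher number here means a weaker inhibitor, a lower number a stronger inhibitor), compound 1 gives 260 nM, the highest of the two numbers recorded. The value for compound 2 is a limit of this assay, (the limit of > 5000 nM in this assay, at which 1 of the 3 values shown sits). Compound 3, by contrast, sits at 27 nM, so the step of a 9.6-fold lower number from compound 1 to compound 3 (0.98 log units; beyond the scatter) is beyond the scatter, and an at least 19-fold higher number from compound 1 to compound 2 (1.28 log units; beyond the scatter) as well as an at least 180-fold lower number from compound 2 to compound 3 (2.26 log units; beyond the scatter) show that removing the ester alkyl group altogether costs much more than reshaping it.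

Compound 4 `CCCCCCCCCCOC(=O)CC(=O)Nc1c(C(C)C)cccc1C(C)C` extends the chain: ethyl in place of hydrogen on a saturated chain carbon, eight bonds along the chain from an oxygen next to a carbonyl group. Among the compounds with values here, no measured step covers chain lengthening on its own; 1>2 and 1>3 bear on it only by showing that the ester group matters and its shape shifts potency modestly. A change in this assay within or near the scatter is therefore expected, with no strong directional call.

Compound 4 is estimated at 220 nM, range 60 nM to 800 nM, which is expected to mean a 1.2-fold lower number from compound 1 to compound 4 (0.07 log units; within the scatter).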

Compound 4, half-maximal inhibitory concentration: 53 nM
Compound 4: middle estimate off by 4.2-fold (0.62 log units), on the high side, and the stated range ends above it.
By their numbers in this assay, from the lowest: compounds 3 and 4 (each within the scatter of the next); then compound 1. At a limit, above all of these: compound 2.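

In this assay, adding ethyl on the saturated chain carbon, eight bonds along the chain from an oxygen next to a carbonyl group, is not a neutral change: a 4.9-fold lower number from compound 1 to compound 4 (0.69 log units; beyond the scatter). Within the data shown here, earlier steps showed only that the ester alkyl group matters and that exchanging octyl for 1-methylhexyl shifts the number; this step shows that the outer end of an unbranched chain also registers, so length alone moves potency. Nothing measured here accounts for the gain.

As far as these compounds go, a single step sets no trend, so it remains open whether a shorter chain such as butyl or a longer one such as dodecyl would continue the direction or reverse it. Also open, from the compounds shown here alone, is whether a 1-methyl branch on the decyl chain would add to the effect of lengthening.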